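The source may hold more compounds than are shown below. What is called first, only, known or untested is meant among the compounds shown, and "the series" means these compounds.

Of the compounds shown here, three have been measured in an assay for inhibition of Polyunsaturated fatty acid 5-lipoxygenase (Homo sapiens), read by spectrophotometry, tested at 10 uM; a lower number here means less inhibition, a higher number more inhibition at the concentration tested (going by the name of the read-out). Compound 1 `O=C(c1ccccc1)c1sc(N2CCN(c3ccccc3)CC2)nc1-c1ccccc1` gives 38.3% in this assay. Compound 2 `O=C(NC(=S)N1CCN(c2ccccc2)CC1)c1ccc([N+](=O)[O-])cc1` reaches 76.6%, the highest of the three, while compound 3 `O=C(NC(=S)N1CCN(c2ccccc2)CC1)c1ccc(F)cc1` gives 23.6%. Compound 3 therefore stands lowest of the three numbers: compound 1 is nearest above it and compound 2 furthest, and both gaps lie beyond the usual scatter.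

Compound 4 `COc1ccc(C(=O)NC(=S)N2CCN(c3ccccc3)CC2)cc1` is the next to be tested. It differs from compound 3 in one place: methoxy in place of fluoro on an aromatic carbon.

Within the data shown here, one measured step touches the same place on the ring. There, a number 53 percentage points lower from compound 2 to compound 3 (beyond the scatter), which shows that the group at this position can shift the read-out a long way. Among the measured compounds shown here, no measured step, however, exchanges fluoro for methoxy, so neither the direction nor the size of the present change is fixed by the data; it can only be said that a group other than nitro at this spot gave a low number in compound 3. On that basis a small rise is expected for compound 4, within reach of the scatter, and the step of a number 8.4 percentage points higher from compound 3 to compound 4 (within the scatter) is the estimate. Compound 4 is thus expected to give about 32%, somewhere between 10% and 58%.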

Compound 4, a percentage reported as inhibition, at one concentration (the size of the read-out at that concentration, not a potency): 36.8%
For compound 4 the middle estimate is 4.8 percentage points below the measured one, within the range that was stated.
By their numbers in this assay, from the lowest: compound 3; then compounds 4 and 1 (each within the scatter of the next); then compound 2.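

Exchanging fluoro for methoxy at this position gives, in this assay, a number 13.2 percentage points higher from compound 3 to compound 4 (beyond the scatter), so even a swap between two groups other than nitro moves the number, although only modestly. Measured against the nitro compound, the same position shows a number 39.8 percentage points lower from compound 2 to compound 4 (beyond the scatter), so the large fall seen earlier is not peculiar to fluoro: of the three groups tried on this carbon, nitro stands clearly above both of the others. No measurement at hand speaks to why the three groups fall in this order.

As far as these compounds go, three groups on one carbon make a short series, so it remains open whether a nitrile, a carboxylic acid or an amine in this place would reach the high number of nitro or stay closer to methoxy and fluoro. Also open, from the compounds shown here alone, is what a longer chain in place of methoxy would give, and whether nitro would keep its lead on another carbon of the same ring.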